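Amide Cap Change in a Urotensin Receptor Ligand Series

The compounds below may be only part of what the source reports. "The series", "measured", "known", "first", "only" and "open" are said of these compounds alone.

Compound 3 `CC(C)C[C@H](NC(=O)c1cc2ccccc2[nH]1)C(=O)N[C@H]1CCN(Cc2ccc(OCCCN(C)C)cc2)C1` is the larger member of the set, and in an assay on HEK293 cells for binding affinity to Urotensin-2 receptor (Homo sapiens), read by radioligand binding (a lower number here means a stronger inhibitor, a higher number a weaker inhibitor), compound 3 gives 501 nM. Of the two numbers obtained so far this is the lower; the nearest is compound 2 `CN(C)CCCOc1ccc(CN2CC[C@H](NC(=O)c3ccccc3)C2)cc1`, which in this assay gives 2510 nM, a gap beyond the scatter. Compound 1 `CN(C)CCCOc1ccc(CN2CC[C@H](NC(=O)c3ccc(-c4ccccc4)cc3)C2)cc1` returns only a limit in this assay, < 10000 nM. Among the compounds with values here, the single one-place step recorded, a step that the limit leaves unreadable from compound 1 to compound 2, is unreadable because of the limit of < 10000 nM in this assay, at which 1 of the 3 values shown sits.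

Compound 4 `CC(C)C[C@H](NC(=O)c1ccc(Cl)c(Cl)c1)C(=O)N[C@H]1CCN(Cc2ccc(OCCCN(C)C)cc2)C1` differs from compound 3 by 3,4-dichlorophenyl in place of 1H-indol-2-yl on a carbonyl carbon. Within the data shown here, no measured step touches the amide cap: the only recorded step concerns a different position and cannot be sized. The measured pairs therefore give no direction for this change, and a step of about the scatter, with wide uncertainty either way, is expected. Compound 4 is estimated at 600 nM in this assay, with a range from 150 nM to 2500 nM. The step expected from this estimate is a 1.2-fold higher number from compound 3 to compound 4 (0.08 log units; within the scatter), small and uncertain in sign.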

Compound 4, inhibition constant: 126 nM
For compound 4 the middle estimate is 4.8-fold (0.68 log units) above the measured one; the measured number lies below the stated range.
By their numbers in this assay, from the lowest: compound 4; then compound 3; then compound 2.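

In this assay the amide cap proves responsive, with a 4.0-fold lower number from compound 3 to compound 4 (0.60 log units; beyond the scatter) on replacing 1H-indol-2-yl by 3,4-dichlorophenyl. Within the data shown here, this is the first readable step, and it shows that the hydrogen-bond donor of 1H-indol-2-yl is not needed to reach the lowest number so far, since the entering group carries no donor. No measured property in hand bears on this step.

A single pair cannot show whether the step follows the two chlorine atoms or the change from the two-ring 1H-indol-2-yl to a single six-membered ring, and the step involving the limit for compound 1 remains unreadable. On these data alone, how a phenyl cap bearing one chlorine, a methoxy group, a carboxylic acid or an amine would compare with compound 4 also remains open.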